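A Five-Membered Ring Replaces a Methylated Six-Membered Ring

The source may hold more compounds than are shown below. What is called first, only, known or untested is meant among the compounds shown, and "the series" means these compounds.

Three compounds share one core and differ only in the amine on the outer aromatic ring. Compound 1 `CCCN(CCC)c1ccc(Nc2ncc(Cl)c(Oc3cccc(NC(=O)CC)c3)n2)cc1` carries dipropylamino and in an assay on isolated protein for inhibition of NUAK family SNF1-like kinase 1 (Homo sapiens), read by ADP-Glo, with a stated time of 60 min, tested at 10 uM, in the presence of a further agent that is not named here (on this read-out lower numbers stand for less inhibition and higher numbers for more inhibition at the one concentration tested (going by the name of the read-out)), compound 1 gives 9.3%. Compound 2 `CCC(=O)Nc1cccc(Oc2nc(Nc3ccc(N4CCCCC4)cc3)ncc2Cl)c1` carries piperidin-1-yl and in this assay compound 2 gives 86%. Compound 3 `CCC(=O)Nc1cccc(Oc2nc(Nc3ccc(N4CCC(C)CC4)cc3)ncc2Cl)c1` carries 4-methylpiperidin-1-yl and in this assay compound 3 gives 13.4%, the second highest of the three numbers; the step of a number 4.1 percentage points higher from compound 1 to compound 3 (within the scatter) stays within the scatter, while the step of a number 72.6 percentage points lower from compound 2 to compound 3 (beyond the scatter) is a large drop.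

Compound 4 `CCC(=O)Nc1cccc(Oc2nc(Nc3ccc(N4CCCC4)cc3)ncc2Cl)c1` is the next step: pyrrolidin-1-yl in place of 4-methylpiperidin-1-yl on an aromatic carbon. For the measured compounds named here, no measured step copies this change. The step of a number 72.6 percentage points lower from compound 2 to compound 3 (beyond the scatter) shows that one methyl on the saturated ring carbon matters greatly, and a number 76.7 percentage points higher from compound 1 to compound 2 (beyond the scatter) shows that the shape of the amine matters as much. Compound 4 has no methyl, like compound 2, but a smaller ring than any measured compound, so the outcome is open.

Compound 4 is therefore expected to give 50%, with the estimate spanning 10% to 90%. The expected step is a number 36.6 percentage points higher from compound 3 to compound 4 (beyond the scatter), most likely upward but uncertain.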

Compound 4, a percentage reported as inhibition, at one concentration (the size of the read-out at that concentration, not a potency): "not active" (no number reported)
No number was reported for compound 4, so the estimate cannot be set against anything.
By their numbers in this assay, from the lowest: compounds 1 and 3 (each within the scatter of the next); then compound 2.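

In this assay, for the compounds shown here, compound 4 is reported only as not active, with no number, so no step from compound 4 to compound 1, compound 2 or compound 3 can be read. The compounds shown leave open how the pyrrolidin-1-yl of compound 4 compares numerically with the other amines. No evidence here accounts for this result.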